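The source may report more compounds than this note shows. Statements on the series, on what has been measured and on what is new or still open speak of the compounds shown alone.

Working notes on the series. Compound 1 `O=C(NCCO)c1cc(-c2ccc(Cl)cc2Cl)n[nH]1` and compound 2 `O=C(c1cc(-c2ccc(Cl)cc2Cl)n[nH]1)N1CCOCC1` share the same core and differ only in the group on the carbonyl carbon. In an assay on isolated protein for inhibition of alkaline phosphatase, tissue-nonspecific isozyme (Homo sapiens) (a higher number here means a weaker inhibitor, a lower number a stronger inhibitor), compound 1 gives 44 nM; in this assay compound 2 gives 574 nM. The step of a 13-fold higher number from compound 1 to compound 2 (1.12 log units; beyond the scatter) shows that the substituent on the carbonyl carbon matters a great deal for this assay. Among the two numbers measured, compound 2 holds the highest; its only neighbour, compound 1, sits far lower.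

Compound 3 `O=C(c1cc(-c2ccc(Cl)cc2Cl)n[nH]1)N1CCCCCC1` is not yet measured. It differs from compound 2 in one place: azepan-1-yl in place of morpholin-4-yl on a carbonyl carbon. Among the measured compounds shown here, no measured step mirrors this exchange of one saturated ring for another, so the only guide is the size of the one step that exists on this carbonyl carbon, which was large. From compound 2 the direction of the step is therefore open; a modest move is expected, with wide uncertainty, a 1.2-fold higher number from compound 2 to compound 3 (0.09 log units; within the scatter). For compound 3 in this assay the estimate is 700 nM, within a range from 200 nM to 2500 nM.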

Compound 3, half-maximal inhibitory concentration: 1450 nM
The estimate for compound 3 lay 2.1-fold (0.32 log units) below the measured number; measured number inside the range.
By their numbers in this assay, from the lowest: compound 1; then compound 2; then compound 3.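

With azepan-1-yl in place of morpholin-4-yl on the carbonyl carbon, this assay gives a 2.5-fold higher number from compound 2 to compound 3 (0.40 log units; beyond the scatter), a modest step but one beyond the scatter, so this position still distinguishes between two saturated rings that each count no hydrogen-bond donors. The comparison with the (2-hydroxyethyl)amino group of compound 1 gives a 33-fold higher number from compound 1 to compound 3 (1.52 log units; beyond the scatter), the largest of the three steps on this carbonyl carbon, and neither of the two ring groups comes near compound 1 in this assay. No measurement at hand explains why the numbers differ among these groups.

Morpholin-4-yl and azepan-1-yl differ in both ring size and ring oxygen, so the compounds shown leave open which of the two changes accounts for the step, a question that piperidin-1-yl on the same carbonyl carbon would help to separate. Also open, on these data alone, is how a longer chain such as (3-hydroxypropyl)amino, or a capped chain such as (2-methoxyethyl)amino, would compare with the (2-hydroxyethyl)amino group of compound 1.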